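Series notes: methyl to ethyl at the aromatic nitrogen

A few compounds are considered here, and "the series" means these few. Any claim that something is new, unique, unknown or untested is made for them only; others in the source may bear on it.

Measured so far:
compound 1, `Oc1nnc(-c2cccnc2)c2ccccc12`: 26%
compound 2, `Cn1nc(-c2cccnc2)c2ccccc2c1=O`: 63%

In an assay on isolated protein (Oryctolagus cuniculus) with Thromboxane-A synthase (Homo sapiens) as the target, tested at 1 uM (on this read-out higher numbers stand for more inhibition at the one concentration tested (going by the name of the read-out) and lower numbers for less inhibition), compound 2 gives 63%, the higher of the two numbers recorded; compound 1 gives 26%, lower by a margin beyond the usual scatter. Going by the values given here, no pair of measured compounds differs in one place only, so no single structural step has yet been measured on this scale.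

Compound 3, `CCn1nc(-c2cccnc2)c2ccccc2c1=O`, is the next compound for this assay. Relative to compound 2 it carries methyl in place of hydrogen on a saturated chain carbon bound to an aromatic nitrogen. Among the compounds with values here, no measured step shows how a change of this kind reads here. The expectation is anchored on compound 2 at 63%, with a step of a number 3 percentage points lower from compound 2 to compound 3 (within the scatter) that is expected to stay within the scatter, in either direction. Compound 3 is estimated at 60%, with a range from 40% to 80%.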

Compound 3, a percentage reported as inhibition, at one concentration (the size of the read-out at that concentration, not a potency): 87%
Compound 3: middle estimate off by 27 percentage points, on the low side, and the stated range ends below it.
By their numbers in this assay, from the lowest: compound 1; then compound 2; then compound 3.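

Methyl to ethyl, on a saturated chain carbon bound to an aromatic nitrogen, gives the first single-place step in this series: in this assay it reads a number 24 percentage points higher from compound 2 to compound 3 (beyond the scatter) and so shows that this position responds to the read-out. One added carbon is enough to raise the inhibition at the one concentration tested, so ethyl is accepted here and is the better of the two groups compared. Nothing measured here gives a reason for the gain.

As far as these compounds go, whether the gain continues with a longer chain such as propyl or butyl, or reverses, stays open, as does the reading of a branched isopropyl or of a chain ending in an amine or a carboxylic acid. A single step describes only compound 2 and compound 3, and sets no trend along the chain.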